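Methoxy on the Phenyl Ring: Expecting Compound 4

The source may hold more compounds than are shown below. What is called first, only, known or untested is meant among the compounds shown, and "the series" means these compounds.

Of the compounds shown here, three have been tested in a toxicity assay on HeLa cells (Homo sapiens) for cytotoxicity, read by MTT assay, with a stated time of 24 h; a lower number here means a stronger inhibitor, a higher number a weaker inhibitor. Compound 1 `Cc1ncc([N+](=O)[O-])n1CC(O)CSC(=S)N1CCN(c2ccccc2)CC1` carries a plain phenyl group. In this assay compound 1 reaches only the limit of the measurement, > 5000000 nM. Compound 2 `COc1ccccc1N1CCN(C(=S)SCC(O)Cn2c([N+](=O)[O-])cnc2C)CC1` differs from it by methoxy in place of hydrogen on an aromatic carbon. In this assay compound 2 likewise gives only a limit, > 5000000 nM. The step that the two limits leave unreadable from compound 1 to compound 2 therefore cannot be sized. Compound 3 `Cc1ncc([N+](=O)[O-])n1CC(O)CN1CCN(c2ccccc2)CC1` has a different core; how its core differs from the core of compound 1 is not broken down here. In this assay compound 3 also gives only a limit, > 5000000 nM. Compound 4 `COc1ccccc1N1CCN(CC(O)Cn2c([N+](=O)[O-])cnc2C)CC1`, not yet measured, is made from compound 3 by methoxy in place of hydrogen on an aromatic carbon, the same change that turns compound 1 into compound 2, with the same surroundings around the place. Because (the limit of > 5000000 nM in this assay, at which 3 of the 3 values shown sit), no readable step appears anywhere in this set, and the same change already left compound 1 and compound 2 both at that limit. The step is expected to be a number no higher from compound 3 to compound 4 (the limit leaves the size open), essentially flat. Compound 4 is estimated at 5000000 nM, most likely reported again only as a limit.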

Compound 4, half-maximal inhibitory concentration: 4390000 nM
Compound 4: the middle estimate sits 1.1-fold (0.06 log units) above what was measured; measured number inside the range.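

On the core of compound 3, placing methoxy on the phenyl ring gives an at least 1.1-fold lower number from compound 3 to compound 4 (0.05 log units; that floor lies within the scatter) in this assay, so this pair alone does not establish a real difference. The same change on the core of compound 1 cannot be read, as both of its values are limits, which leaves no second size to set against this one. Nothing here therefore shows that methoxy acts alike on the two cores, or that it has any effect on either, and the result is only consistent with a small effect: the limit of > 5000000 nM in this assay, at which 3 of the 4 values shown sit.

The compounds shown carry only hydrogen or methoxy at this place on the phenyl ring, so it stays open whether an amine or a carboxylic acid there would give a number clearly apart from the others. Also open, as far as these compounds go, is whether a longer chain between the two ring systems would move compound 4 clearly in this assay.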